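The compounds below may be only part of what the source reports. "The series", "measured", "known", "first", "only" and "open" are said of these compounds alone.

Compound 1 `OC(c1ccc(Cl)cc1)(c1ccc(Br)cc1)c1cncnc1`: 58700 nM
Compound 2 `COC(c1ccc(Cl)cc1)(c1cccnc1)c1ccccc1Cl`: 58700 nM
Compound 3 `NC(c1ccc(Cl)cc1)(c1cccnc1)c1ccccc1Cl`: 76000 nM

In an ADME assay on L6 cells (Rattus norvegicus) for cytotoxicity, read by resazurin assay, with a stated time of 72 h (a higher number here means a weaker inhibitor, a lower number a stronger inhibitor), compound 3 lies within the scatter of both compound 1 and compound 2. Compound 4 `Clc1ccc(C(c2cccnc2)c2ccccc2Cl)cc1` differs from compound 3 by one change: hydrogen in place of amino on a saturated chain carbon bound to three aromatic carbons. Among the compounds with values here, the only measured step at this carbon is a 1.3-fold higher number from compound 2 to compound 3 (0.11 log units; within the scatter), where amino in place of methoxy stayed within the scatter. Within the data shown here, no measured pair tests hydrogen at this carbon, so the evidence is indirect. Taken with the close values of all three compounds, it gives no reason to expect a step beyond the scatter. The expected step is a 1.4-fold lower number from compound 3 to compound 4 (0.14 log units; within the scatter). Compound 4 is estimated at 55000 nM, with an expected range from 25000 nM to 110000 nM.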

Compound 4, half-maximal inhibitory concentration: 62300 nM
Estimate against measurement, compound 4: 1.1-fold (0.05 log units) below, within the range that was stated.
By their numbers in this assay, from the lowest: compounds 1, 2, 4 and 3 (each within the scatter of the next).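

In this assay, the saturated chain carbon bound to three aromatic carbons gave no step beyond the scatter when it carried only hydrogen: hydrogen in place of amino gave (a 1.2-fold lower number from compound 3 to compound 4 (0.09 log units; within the scatter)), and hydrogen in place of methoxy gave (a 1.1-fold higher number from compound 2 to compound 4 (0.03 log units; within the scatter)). Across compound 2, compound 3 and compound 4, the read-out therefore did not depend on having amino or methoxy at this carbon. No evidence is available to explain this. On these data alone, it remains open whether a carboxylic acid or a longer chain at this carbon would give a step beyond the scatter.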